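Taking Away One Methyl Group from Compound 2

The source may hold more compounds than are shown below. What is called first, only, known or untested is meant among the compounds shown, and "the series" means these compounds.

Of the compounds shown here, three have so far been tested in a functional assay on CHO cells for agonist activity at Alpha-1D adrenergic receptor (Homo sapiens), read by FLIPR and calcium flux; on this read-out higher numbers stand for an effect only at larger amounts of compound and lower numbers for an effect already at smaller amounts. Compound 1 `c1ccc(-c2cccc3c2CCC3c2ncc[nH]2)nc1` gives > 10000 nM, which is a limit of the assay rather than a number. Compound 2 `COc1c(C)ccc2c1CCC2c1ncc[nH]1` gives > 10000 nM, again only a limit. Compound 3 `Cc1c(OCC2=NCCN2)ccc(Cl)c1NS(C)(=O)=O` gives > 10000 nM, once more a limit. Compound 2 therefore stands exactly where the others stand: the limit of > 10000 nM in this assay, at which 3 of the 3 values shown sit, with no real number that would set it apart from either of them.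

Compound 4 `COc1cccc2c1CCC2c1ncc[nH]1` has not yet been measured. It differs from compound 2 in a single place: hydrogen in place of methyl on an aromatic carbon, in words, hydrogen in place of methyl on an aromatic carbon. For the measured compounds named here, no pair of measured compounds differs in only one place, so no measured step shows what such a removal does in this assay. All that is known is that compound 2 reaches only a limit, and a change of this size is expected to leave that unchanged, with no step beyond the scatter. The most likely result is that compound 4 again returns only a limit, and its value is estimated at 20000 nM, in a range from 5000 nM to 100000 nM. The expected step that the limit leaves unreadable from compound 2 to compound 4 is thus essentially none.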

Compound 4, half-maximal effective concentration: > 10000 nM
Compound 4: a limit, no number; the forecaster's own chance of this, stated with the estimate: 85%; the middle value does not contradict the limit.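

In this assay compound 4 gives > 10000 nM, a limit and not a number. With limits on both sides, no step can be read from compound 2 or from compound 1 to compound 4. The compounds shown leave open what hydrogen in place of methyl does to the real value, since none of them has a number here.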